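Turning Compound 1 into Its Mirror Image

The source may hold more compounds than are shown below. What is called first, only, known or untested is meant among the compounds shown, and "the series" means these compounds.

Of the compounds shown here, three sharing one core have been measured in a functional assay on MCF7 cells (Homo sapiens) for antiproliferative activity, read by sulforhodamine B assay, with a stated time of 48 h; a higher number here means a weaker inhibitor, a lower number a stronger inhibitor. Compound 1 `CC(C)(C)OC(=O)NCCC[C@@H]1N=C2C[C@@H]3C[C@@H](C3(C)C)[C@]2(C)OC1=O` gives 6300 nM, the lowest number of the three. Compound 2 `C[C@H]1N=C2C[C@H]3C[C@H](C3(C)C)[C@@]2(C)OC1=O` gives 38000 nM in this assay, the nearest neighbour of compound 1, yet its step from compound 1 lies beyond the scatter. Compound 3 `CC1(C)[C@H]2CC[C@]1(C)[C@H]1OC(=O)CN=C21` gives 135000 nM in this assay and stands furthest from compound 1, again beyond the scatter. Compound 1 is therefore the strongest inhibitor among the measured three.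

Compound 4 `CC(C)(C)OC(=O)NCCC[C@H]1N=C2C[C@H]3C[C@H](C3(C)C)[C@@]2(C)OC1=O` has not yet been measured. Its relation to compound 1 is this: the two compounds have the same atoms and bonds and differ only in configuration as drawn: 4 of 4 stereo elements differ (all stereocentres are inverted: mirror images); a stereocentre at a saturated ring carbon is drawn S in compound 1 and R in compound 4; a stereocentre at a saturated ring carbon is drawn S in compound 1 and R in compound 4; a stereocentre at a saturated ring carbon is drawn S in compound 1 and R in compound 4; a stereocentre at a saturated ring carbon is drawn S in compound 1 and R in compound 4. Going by the values given here, no pair of measured compounds differs only in configuration, so the series itself gives no direct guide to how large such a step may be. A complete inversion of configuration can leave the number unchanged or shift it far in either direction. Here a moderate move toward a higher number, beyond the scatter, is expected, carrying wide uncertainty. Compound 4 is accordingly estimated at 13000 nM in this assay, with a range from 3500 nM to 60000 nM. The step this estimate implies is a 2.1-fold higher number from compound 1 to compound 4 (0.31 log units; beyond the scatter), expected to show compound 4 as the weaker of the pair.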

Compound 4, half-maximal inhibitory concentration: 56000 nM
The estimate for compound 4 lay 4.3-fold (0.63 log units) below the measured number; the range from low to high includes it.
By their numbers in this assay, from the lowest: compound 1; then compounds 2 and 4 (each within the scatter of the next); then compound 3.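

In this assay the series now holds its first step that can be read for configuration alone, and it is an 8.9-fold higher number from compound 1 to compound 4 (0.95 log units; beyond the scatter). Going by these compounds alone, the spatial arrangement of the molecule therefore matters in this read-out, since the number moves with no atom or bond leaving or entering, and of the two mirror images compound 1 is the one with the lower number: the fact that compounds 1 and 4 differ only in the configuration as drawn. The earlier compounds shown here, which differ from one another in more than configuration, put no size on such a change.

The compounds shown leave open which of the four stereocentres carries this step, or whether all of them share in it. They also leave open whether a free amine or a carboxylic acid in place of the tert-butyl carbamate, or a longer chain, would keep the same gap between the two mirror-image forms.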